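Swapping nitro for methylsulfonyl: a solubility estimate

The compounds below may be only part of what the source reports. "The series", "measured", "known", "first", "only" and "open" are said of these compounds alone.

Measured in a physicochemical assay for solubility, read by spectrophotometry, in phosphate buffer, with a stated time of 18 h, at pH 7.4; a lower number here means a less soluble compound, a higher number a more soluble compound:
- compound 1 `Cc1nn(-c2ccccc2)c2nc(-c3ccc(C(C)C)cc3)c(C#N)c(-c3ccccc3O)c12`: 9800 nM
- compound 2 `Cc1nn(-c2ccccc2)c2nc(-c3ccc([N+](=O)[O-])cc3)c(C#N)c(-c3ccccc3O)c12`: 6000 nM

Compound 2 cannot be told apart from compound 1 on these numbers, since the two lie within the scatter of each other. Repeat measurements of one compound can differ by that much.

The next structure is compound 3 `Cc1nn(-c2ccccc2)c2nc(-c3ccc(S(C)(=O)=O)cc3)c(C#N)c(-c3ccccc3O)c12`. It keeps the shared core and carries methylsulfonyl in place of nitro on an aromatic carbon, para to a large group: methylsulfonyl in place of nitro on an aromatic carbon.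

For the measured compounds named here, only one measured step bears on this change, and it also exchanges a single group on an aromatic carbon. That step is a 1.6-fold lower number from compound 1 to compound 2 (0.21 log units; within the scatter). Going by the values given here, no compound with methylsulfonyl has been measured yet, so the evidence is thin. A step beyond the scatter in this assay is therefore not expected, and no firm direction can be given.

The expected step is a 1.2-fold higher number from compound 2 to compound 3 (0.07 log units; within the scatter). For compound 3 the estimated value is 7000 nM, with an expected range from 2800 nM to 16000 nM.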

Compound 3, solubility: 5000 nM
The estimate for compound 3 lay 1.4-fold (0.15 log units) above the measured number; the range from low to high includes it.
By their numbers in this assay, from the lowest: compounds 3, 2 and 1 (each within the scatter of the next).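

In this assay the aromatic carbon para to a large group has now carried three different groups, and every exchange stays within the scatter: methylsulfonyl in place of nitro gives a 1.2-fold lower number from compound 2 to compound 3 (0.08 log units; within the scatter) and methylsulfonyl in place of isopropyl gives a 2.0-fold lower number from compound 1 to compound 3 (0.29 log units; within the scatter) at the same position. Isopropyl, nitro and methylsulfonyl therefore cannot be told apart at this position in this assay, and the earlier pair alone could not show that this holds for a third group as well. No measurement of any other property of these compounds bears on this result, so nothing can be said about what lies behind it.

Still open, from the compounds shown here alone, is whether any group on this carbon can move the number beyond the scatter: an amine, a carboxylic acid or a longer chain in the same place could answer that. Also open, going by these compounds, is whether these three groups would still read alike with a different group elsewhere on the shared core.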